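Aryl swap at the ring carbon leaves inhibition flat

The source may hold more compounds than are shown below. What is called first, only, known or untested is meant among the compounds shown, and "the series" means these compounds.

Compound 3 `CC(C)(C)Cc1c(-c2ccccc2)sc(N)c1C(=O)c1ccc(Cl)cc1` is one of three close relatives that share a core and differ only in the aryl group on an aromatic carbon of the five-membered ring. In an assay on CHO cells for displacement of a labelled ligand from adenosine receptor A3 (Homo sapiens), read by scintillation counting, tested at 10 uM (on this read-out lower numbers stand for less inhibition and higher numbers for more inhibition at the one concentration tested (going by the name of the read-out)), compound 3 gives 1%. Compound 1 `CC(C)(C)Cc1c(-c2ccccn2)sc(N)c1C(=O)c1ccc(Cl)cc1` gives 1% in this assay, and compound 2 `CC(C)(C)Cc1c(-c2ccc(Cl)c(Cl)c2)sc(N)c1C(=O)c1ccc(Cl)cc1` gives 1%. Compound 3 thus stands level with both: no change at the digits printed from compound 1 to compound 3 (within the scatter) and no change at the digits printed from compound 2 to compound 3 (within the scatter), and the pair of the others shows no change at the digits printed from compound 1 to compound 2 (within the scatter). Compound 4 `Cc1noc(C)c1-c1sc(N)c(C(=O)c2ccc(Cl)cc2)c1CC(C)(C)C` is the next member, with the change (3,5-dimethyl-1,2-oxazol-4-yl in place of phenyl on an aromatic carbon). The three steps that bear on it all exchange one aryl group for another at the same ring carbon, and none of them moved the read-out beyond the scatter. On that basis compound 4 is expected to show a number 1 percentage points higher from compound 3 to compound 4 (within the scatter), no step beyond the scatter in either direction. Compound 4 is therefore estimated at 2%, with a range from -8% to 12%.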

Compound 4, a percentage reported as inhibition, at one concentration (the size of the read-out at that concentration, not a potency): 1%
Compound 4: the middle estimate sits 1 percentage points above what was measured; low and high end bracket the measured number.
By their numbers in this assay, from the lowest: compounds 1, 2, 3 and 4 (each within the scatter of the next).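

With the 3,5-dimethyl-1,2-oxazol-4-yl group at this ring carbon, this assay shows no change at the digits printed from compound 3 to compound 4 (within the scatter) and no change at the digits printed from compound 2 to compound 4 (within the scatter) and also no change at the digits printed from compound 1 to compound 4 (within the scatter) in the same read-out. The earlier compounds shown here carried only six-membered aromatic rings here, so the flat result now extends to a five-membered aromatic ring with 2 hetero atoms and 2 hydrogen-bond acceptors, where phenyl has none. Among these four compounds, no aromatic group at this carbon separates from the others.

From the compounds shown here alone, whether a non-aromatic group at this carbon, such as a morpholine, a carboxylic acid or a longer alkyl chain, would move the number remains open, as does any change to the neopentyl or amino groups, which stay the same throughout. Nothing available here bears on why the read-out stays flat.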